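This account rests on a few compounds, and the source may have more. Where it says the series, first, only, none or still open, it means among the compounds named here.

Measured so far:
compound 1 `COc1ccc(N2C(=O)COc3ccc(-c4cnc(OC)c(NS(=O)(=O)c5ccc(F)cc5)c4)cc32)cc1` — 1220 nM
compound 2 `O=C1COc2ccc(-c3cnc(Cl)c(NS(=O)(=O)c4ccc(F)cc4)c3)cc2N1c1ccccc1` — 10300 nM

In a functional assay on HeLa cells (Homo sapiens) for antiproliferative activity, read by MTT assay, with a stated time of 72 h (on this read-out lower numbers stand for stronger inhibition and higher numbers for weaker inhibition), compound 1 gives 1220 nM, and compound 2 gives 10300 nM. Compound 2 thus has the higher number of the two, and its gap to compound 1 lies beyond the usual scatter. The two compounds differ in more than one place, so no single change between them can be read off, and nothing is set down here about what drives that gap.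

Compound 3 `CC(C)N1C(=O)COc2ccc(-c3cnc(Cl)c(NS(=O)(=O)c4ccc(F)cc4)c3)cc21` has not been measured. It differs from compound 2 in one place only: isopropyl in place of phenyl on an amide-type nitrogen in a ring. Among the compounds with values here, no pair of measured compounds shows this change, so no step for it is known from the series itself. In this assay the step of a 1.3-fold lower number from compound 2 to compound 3 (0.11 log units; within the scatter) is expected to stay within the scatter, with no firm direction. Compound 3 is expected to give about 8000 nM, with a range from 2500 nM to 25000 nM.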

Compound 3, half-maximal inhibitory concentration: 5380 nM
The estimate for compound 3 lay 1.5-fold (0.17 log units) above the measured number; low and high end bracket the measured number.
By their numbers in this assay, from the lowest: compound 1; then compounds 3 and 2 (each within the scatter of the next).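

In this assay, within the data shown here, isopropyl in place of phenyl on the amide-type nitrogen in a ring gives a 1.9-fold lower number from compound 2 to compound 3 (0.28 log units; within the scatter) and provides the first step that can be read at a single place. With the rest of compound 2 held constant, this position therefore accepts a chain-like group with no ring in place of the six-membered aromatic ring without a step beyond the scatter. No measurement bears on why this exchange leaves the number within the scatter.

As far as these compounds go, whether the same exchange behaves alike with the methoxy-bearing structure of compound 1 remains open, as does what drives the gap between compound 1 and the other two compounds, which differ from it in more than one place. From the compounds shown here alone, it is also open how this nitrogen would tolerate a longer chain, an amine or a carboxylic acid.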